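This account rests on a few compounds, and the source may have more. Where it says the series, first, only, none or still open, it means among the compounds named here.

Compound 1, `CCOC(=O)c1oc2ccc(NS(=O)(=O)c3ccc(F)cc3)cc2c1C`, in a functional assay on HCT-116 cells (Homo sapiens) for inhibition, read by MTT assay, with a stated time of 72 h (a higher number here means a weaker inhibitor, a lower number a stronger inhibitor), gives > 40000 nM, which is a limit of the assay rather than a number.
Compound 2, `CCOC(=O)c1oc2ccc(N(Cc3ccccc3)S(=O)(=O)c3cccc(Br)c3)cc2c1C`, in this assay gives > 40000 nM, also a limit.
Compound 3, `CCOC(=O)c1oc2ccc(N(Cc3ccccc3)S(=O)(=O)c3ccc(C)cc3)cc2c1C`, in this assay gives > 40000 nM, also a limit.

Among the measured compounds shown here, compound 2 therefore stands only at a limit in this assay, and the two further values shown are limits as well, so no measured compound in this set gives a true number; this is summed up in the limit of > 40000 nM in this assay, at which 3 of the 3 values shown sit. The change from compound 2 to compound 4, `CCOC(=O)c1oc2ccc(N(Cc3ccccc3)S(=O)(=O)c3ccc(C(F)(F)F)cc3)cc2c1C`, is 4-(trifluoromethyl)phenyl in place of 3-bromophenyl on a sulfonyl sulfur. For the measured compounds named here, the only measured step that touches the same position is a step that the two limits leave unreadable from compound 2 to compound 3, and the two limits leave its size unreadable. Nothing measured therefore points to a change in this assay beyond the scatter in either direction, and the most likely outcome is that compound 4 also sits at the limit. Compound 4 is expected to give about 60000 nM in this assay, with a range from 20000 nM to 200000 nM. The step this estimate implies, a step that the limit leaves unreadable from compound 2 to compound 4, is expected to stay within the scatter.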

Compound 4, half-maximal inhibitory concentration: 12700 nM
Compound 4: the middle estimate sits 4.7-fold (0.67 log units) above what was measured, and the stated range ends above it.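

Among the compounds shown here, the group on the sulfonyl sulfur can shift the result in this assay: the earlier compounds all sat at a limit, so the steps among them cannot be read, but 4-(trifluoromethyl)phenyl brings the first true number. Putting it in place of 3-bromophenyl gives an at least 3.1-fold lower number from compound 2 to compound 4 (0.49 log units; beyond the scatter), and trifluoromethyl in place of methyl on an aromatic carbon gives an at least 3.1-fold lower number from compound 3 to compound 4 (0.49 log units; beyond the scatter). Both steps start from a limit, so their true size may be greater, and most of this small set still gives no true number: the limit of > 40000 nM in this assay, at which 3 of the 4 values shown sit.

Going by these compounds, whether trifluoromethyl itself matters remains open, and a 4-chlorophenyl or 4-cyanophenyl group on the sulfonyl sulfur would test that. On these data alone, compound 1 differs from compound 4 in more than one place, so the part played by the benzyl group on the sulfonamide nitrogen also stays unknown.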